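The compounds below may be only part of what the source reports. "The series", "measured", "known", "first", "only" and "open" are said of these compounds alone.

Measured in a toxicity assay on SNB-19 cells (Homo sapiens) for cytotoxicity, with a stated time of 24 h; a lower number here means that less compound is tolerated, a higher number that more compound is tolerated:
compound 1 `C=C1CC[C@@H]2[C@](C)(CO)[C@H](O)CC[C@@]2(C)[C@@H]1C/C=C1/C(=O)OC[C@@H]1Oc1cccc2ccc(C)nc12`: > 100000 nM (a limit of the assay, not a number)
compound 2 `C=C1CC[C@@H]2[C@](C)(CO)[C@H](O)CC[C@@]2(C)[C@@H]1C/C=C1/C(=O)OC[C@@H]1Oc1cccc2cccnc12`: 22700 nM

Within the data shown here, compound 2 gives 22700 nM, the only actual number so far in this assay. Compound 1 stands at > 100000 nM, which is a limit only.

Compound 3 `C=C1CC[C@H]2[C@@](C)(CCC(O)[C@@]2(C)CO)[C@@H]1C/C=C1/C(=O)OC[C@H]1Oc1cccc2cccnc12` is the next case, and its difference from compound 2 is this: the two compounds have the same atoms and bonds; at least one stereo element is drawn with a configuration in one of them and without one in the other: 2 of 7 stereo elements differ; a stereocentre at a saturated ring carbon is drawn R in compound 2 and without a configuration in compound 3; a stereocentre at a saturated ring carbon is drawn R in compound 2 and S in compound 3. One saturated ring carbon thus goes from R to S, and another goes from R to no drawn configuration.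

Among the measured compounds shown here, the one measured step, an at least 4.4-fold lower number from compound 1 to compound 2 (0.64 log units; beyond the scatter), is hydrogen in place of methyl on an aromatic carbon. That is a different kind of change, so it bears only indirectly. It shows that a single edit can move the number in this assay, but no stereo change has been measured, so it gives neither size nor direction here.

No step beyond the scatter is expected, in either direction, and confidence is low. The estimate therefore stays anchored on compound 2 at 22700 nM with a wide range. For compound 3 the expected value is 25000 nM, with an estimated range from 9000 nM to 75000 nM. This corresponds to an expected 1.1-fold higher number from compound 2 to compound 3 (0.04 log units; within the scatter).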

Compound 3, half-maximal cytotoxic concentration: 60100 nM
Compound 3: middle estimate off by 2.4-fold (0.38 log units), on the low side; the measured number falls inside the stated range.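

In this assay, a change of drawn configuration alone now moves the number, with atoms and bonds unchanged: a 2.6-fold higher number from compound 2 to compound 3 (0.42 log units; beyond the scatter). The earlier step concerned only hydrogen in place of methyl on an aromatic carbon, so the saturated ring carbons of the shared core now also count as places where this read-out responds, and here the number goes up. The step cannot be assigned to either stereocentre, because one goes from R to S while the other loses its drawn configuration, and what compound 3 contains at that second carbon remains uncertain: the fact that one of compounds 2 and 3 is drawn with a defined configuration and the other without, at the place where they differ.

Open, on these data alone, is which of the two saturated ring carbons carries the step, and whether a form of compound 3 with every stereocentre drawn would give a similar number. Also open, as far as these compounds go, is whether an amine or a carboxylic acid on the aromatic carbon that holds hydrogen in compound 2 would shift the number in this assay, and whether the same configuration change would have a similar effect with the methyl of compound 1 in place.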